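The source may report more compounds than this note shows. Statements on the series, on what has been measured and on what is new or still open speak of the compounds shown alone.

Among the measured compounds shown here, compound 2 `Cc1ccc(NC(=O)/C=C/C(=O)N2C/C(=C\c3ccccc3)C(=O)/C(=C/c3ccccc3)C2)cc1C` stands highest of the two numbers measured so far: in a functional assay on CCRF-CEM cells (Homo sapiens) for cytotoxicity (on this read-out lower numbers stand for stronger inhibition and higher numbers for weaker inhibition), compound 2 gives 7100 nM, whereas compound 1 `O=C(/C=C/C(=O)N1C/C(=C\c2ccccc2)C(=O)/C(=C/c2ccccc2)C1)Nc1ccc(Cl)c(Cl)c1` gives 350 nM. For the measured compounds named here, the only measured step, a 20-fold higher number from compound 1 to compound 2 (1.31 log units; beyond the scatter), shows that the aryl group on the amide-type nitrogen moves the read-out strongly. Compound 3 `COc1ccc(NC(=O)/C=C/C(=O)N2C/C(=C\c3ccccc3)C(=O)/C(=C/c3ccccc3)C2)cc1` carries 4-methoxyphenyl in place of 3,4-dimethylphenyl on an amide-type nitrogen. Going by the values given here, no measured step covers this exact exchange, so the direction is open; the one comparable step only shows that changes at this group can be large. For compound 3 the estimate is accordingly wide, 5000 nM with a range of 1200 nM to 20000 nM. The expected step is a 1.4-fold lower number from compound 2 to compound 3 (0.15 log units; within the scatter).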

Compound 3, half-maximal inhibitory concentration: 510 nM
The estimate for compound 3 lay 9.8-fold (0.99 log units) above the measured number; the whole stated range lies above it.
By their numbers in this assay, from the lowest: compounds 1 and 3 (each within the scatter of the next); then compound 2.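

In this assay, 4-methoxyphenyl on the amide-type nitrogen gives a 14-fold lower number from compound 2 to compound 3 (1.14 log units; beyond the scatter), so the large effect at this position is not confined to the exchange with 3,4-dichlorophenyl. Among the compounds shown here, the exchange of 3,4-dichlorophenyl for 4-methoxyphenyl gives a 1.5-fold higher number from compound 1 to compound 3 (0.16 log units; within the scatter), which leaves 3,4-dimethylphenyl as the only one of the three groups apart from the others. Nothing available explains this split. The compounds shown leave open how an amine or a carboxylic acid in place of the aryl group on this nitrogen would read.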